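Replacing Bromo with Isopropylamino on a Shared Core

The source may hold more compounds than are shown below. What is called first, only, known or untested is meant among the compounds shown, and "the series" means these compounds.

In a functional assay on KB cells (Homo sapiens) for inhibition (a higher number here means a weaker inhibitor, a lower number a stronger inhibitor), compound 1 (`Clc1cc2nc(Cl)n(Cc3ccccc3)c2cc1Cl`) gives > 100000 nM, which is a limit and not a number. Compound 2 (`Clc1cc2nc(Br)n(Cc3ccccc3)c2cc1Cl`) gives > 100000 nM, which is also a limit. So compound 2 stands with its neighbour at the edge of what was read: the limit of > 100000 nM in this assay, at which 2 of the 2 values shown sit.

Compound 3 (`CC(C)Nc1nc2cc(Cl)c(Cl)cc2n1Cc1ccccc1`) carries isopropylamino in place of bromo on an aromatic carbon, between two ring nitrogen atoms: isopropylamino in place of bromo on an aromatic carbon. Within the data shown here, the only measured step that bears on this is a step that the two limits leave unreadable from compound 1 to compound 2. It offers no size to carry over, and it exchanged only one halogen for another, whereas the new change is larger. A modest move towards stronger inhibition is therefore expected, though with little confidence, and another limit is quite possible. The expected step is an at least 1.4-fold lower number from compound 2 to compound 3 (0.15 log units; that floor lies within the scatter). For compound 3 the estimate is 70000 nM, with an expected range of 20000 nM to 200000 nM.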

Compound 3, half-maximal inhibitory concentration: 45000 nM
Compound 3: middle estimate off by 1.6-fold (0.19 log units), on the high side; measured number inside the range.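

In this assay, the position between two ring nitrogen atoms now yields a readable number, as compound 3 gives 45000 nM. Isopropylamino in place of bromo is an at least 2.2-fold lower number from compound 2 to compound 3 (0.34 log units; beyond the scatter), and isopropylamino in place of chloro is an at least 2.2-fold lower number from compound 1 to compound 3 (0.34 log units; beyond the scatter); both are minimum sizes, and the true steps may be larger. The step between the two halogens cannot be read, and only the change to isopropylamino brings this position's effect into view, with the two halogen compounds remaining at a limit: the limit of > 100000 nM in this assay, at which 2 of the 3 values shown sit.

From the compounds shown here alone, it remains open whether the gain follows the amine nitrogen or the branched carbon chain. A plain amino group, a longer butylamino chain or an isopropoxy group at this position would help to separate the two.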